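The source may report more compounds than this note shows. Statements on the series, on what has been measured and on what is new or still open speak of the compounds shown alone.

Working notes on the series in a functional assay on SW 1116 cells (Homo sapiens) for cytotoxicity, read by MTT assay, with a stated time of 48 h; on this read-out higher numbers stand for weaker inhibition and lower numbers for stronger inhibition. Compound 1 `O=C(CSc1nnc(-c2ccncc2)o1)N/N=C/c1ccc(Br)cc1` gives 21300 nM in this assay; compound 2 `O=C(CSc1nnc(-c2ccncc2)o1)N/N=C/c1ccc(O)cc1` gives 12200 nM; compound 3 `COc1cccc(/C=N/NC(=O)CSc2nnc(-c3ccncc3)o2)c1` gives 16500 nM. Compound 3 thus stands second highest of the three numbers, and both of its gaps lie inside the scatter: a 1.3-fold lower number from compound 1 to compound 3 (0.11 log units; within the scatter) to its nearest neighbour, a 1.4-fold higher number from compound 2 to compound 3 (0.13 log units; within the scatter) to its furthest. Going by the values given here, the only other measured swap, hydroxy in place of bromo on an aromatic carbon, gave a 1.7-fold lower number from compound 1 to compound 2 (0.24 log units; within the scatter), again inside the scatter.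

Compound 4 `O=C(CSc1nnc(-c2ccncc2)o1)N/N=C/c1cc(Br)cc(Br)c1O` carries 3,5-dibromo-2-hydroxyphenyl in place of 3-methoxyphenyl on a carbon with a double bond to nitrogen. The entering group combines a hydroxy with bromo, so the swap a 1.7-fold lower number from compound 1 to compound 2 (0.24 log units; within the scatter) bears on it most directly, together with the two aryl exchanges a 1.3-fold lower number from compound 1 to compound 3 (0.11 log units; within the scatter) and a 1.4-fold higher number from compound 2 to compound 3 (0.13 log units; within the scatter); none of these moved this assay beyond the scatter. No step beyond the scatter is therefore expected in either direction. Compound 4 is estimated at 14000 nM, with a range of 5000 nM to 40000 nM, which corresponds to an expected step of a 1.2-fold lower number from compound 3 to compound 4 (0.07 log units; within the scatter).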

Compound 4, half-maximal inhibitory concentration: 8570 nM
Compound 4: middle estimate off by 1.6-fold (0.21 log units), on the high side, within the range that was stated.
By their numbers in this assay, from the lowest: compounds 4, 2, 3 and 1 (each within the scatter of the next, the first and the last beyond it).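

In this assay, going by these compounds alone, the 3,5-dibromo-2-hydroxyphenyl group on the carbon with a double bond to nitrogen gives the first step at this position beyond the scatter, though a modest one: a 2.5-fold lower number from compound 1 to compound 4 (0.40 log units; beyond the scatter). The other two exchanges, a 1.9-fold lower number from compound 3 to compound 4 (0.28 log units; within the scatter) and a 1.4-fold lower number from compound 2 to compound 4 (0.15 log units; within the scatter), stay within the scatter, so the aryl group here is seen to shift the number only against the 4-bromophenyl group, and compounds 2, 3 and 4 cannot be ordered among themselves. No measurement bears on why this step arises.

The compounds shown leave open whether the hydroxy or the two bromo groups account for the step. As far as these compounds go, how an amine or a carboxylic acid on this aryl ring would read in this assay also remains open.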